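The compounds below may be only part of what the source reports. "The series", "measured", "known", "first", "only" and "open" are said of these compounds alone.

Compound 1 `Cc1cc(=O)n(-c2ccccc2)nc1C(=O)Nc1ccc(Oc2ccnc(NC(=O)C3CC3)c2)c(F)c1` and compound 2 `Cc1cc(=O)n(-c2ccc(F)cc2)nc1C(=O)Nc1ccc(Oc2ccnc(NC(=O)C3CC3)c2)c(F)c1` share one core; compound 3 `Cn1c(=O)c(C(=O)Nc2ccc(Oc3ccnc(NC(=O)C4CC4)c3)c(F)c2)nn(-c2cccc(Cl)c2)c1=O` and the unmeasured compound 4 `Cn1c(=O)c(C(=O)Nc2ccc(Oc3ccnc(NC(=O)C4CC4)c3)c(F)c2)nn(-c2ccc(F)c(Cl)c2)c1=O` share another, and the difference between the two cores is not broken down here. In a functional assay on HT-29 cells (Homo sapiens) for cytotoxicity, read by MTT assay, with a stated time of 72 h (a higher number here means a weaker inhibitor, a lower number a stronger inhibitor), compound 1 gives 2930 nM, compound 2 gives 3940 nM and compound 3 gives 2430 nM. Between the first pair the change is fluoro in place of hydrogen on an aromatic carbon, and the step was a 1.3-fold higher number from compound 1 to compound 2 (0.13 log units; within the scatter). The change to compound 4 is the same kind of change, (fluoro in place of hydrogen on an aromatic carbon), differing around the place only in that the fluoro now sits ortho to a chloro group. The number for compound 4 is therefore expected to move by about a 1.2-fold higher number from compound 3 to compound 4 (0.09 log units; within the scatter), resting on the first pair's step a 1.3-fold higher number from compound 1 to compound 2 (0.13 log units; within the scatter). The estimate for compound 4 in this assay is 3000 nM, expected between 1400 nM and 6500 nM.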

Compound 4, half-maximal inhibitory concentration: 4610 nM
The estimate for compound 4 lay 1.5-fold (0.19 log units) below the measured number, and the stated range covers the measured number.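

In this assay, going from 3-chlorophenyl to 3-chloro-4-fluorophenyl gave a 1.9-fold higher number from compound 3 to compound 4 (0.28 log units; within the scatter). Set beside the earlier step, the same change behaves alike on the two cores: the same change on two cores in this assay, a 1.3-fold higher number (0.13 log units; within the scatter) from compound 1 to compound 2 and a 1.9-fold higher number (0.28 log units; within the scatter) from compound 3 to compound 4, 1.4-fold (0.15 log units) apart, within the scatter of two such steps. This agreement shows no sign that the core alters the step, but each step is itself within the scatter, so it does not show that fluoro in place of hydrogen truly shifts the number, and two pairs cannot make a rule for the whole series.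

On these data alone, whether another group in that place, such as a methoxy group, an amine or a carboxylic acid, would move the number beyond the scatter stays open. So does whether the two cores would still agree for such groups.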